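Hydroxy in place of hydrogen: notes on a bromo series

A few compounds are considered here, and "the series" means these few. Any claim that something is new, unique, unknown or untested is made for them only; others in the source may bear on it.

Among the compounds with values here, in an ADME assay on HEK293 cells (Homo sapiens) for cytotoxicity, read by reporter gene assay and resazurin assay, with a stated time of 48 h (on this read-out lower numbers stand for higher toxicity in this test and higher numbers for lower toxicity in this test), compound 2 (`O=C(Nc1cccc(Cl)c1)c1cccc(Br)c1`) gives 51000 nM as the higher of the two numbers so far, and compound 1 (`O=C(Nc1cccc(Cl)c1)c1cc(Br)cc(Br)c1O`) gives 18000 nM as the lower, a gap beyond the scatter.

Compound 3 (`O=C(Nc1cccc(Cl)c1)c1cc(Br)ccc1O`) comes from compound 2 by a single change (hydroxy in place of hydrogen on an aromatic carbon): hydroxy in place of hydrogen on an aromatic carbon, ortho to a large group and para to a bromo group.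

No measured pair isolates this change, so its size in this assay is not shown directly. The expected direction rests on compound 1, which also carries hydroxy and reads 18000 nM with a second bromo group as well, so that gap cannot be credited to hydroxy alone.

A modest move to a lower number, the side of higher toxicity, is expected, with the estimated step of a 2.1-fold lower number from compound 2 to compound 3 (0.33 log units; beyond the scatter) as the working figure. Compound 3 is estimated at 24000 nM with an expected range from 10000 nM to 55000 nM as its half-maximal cytotoxic concentration.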

Compound 3, half-maximal cytotoxic concentration: 15000 nM
Compound 3: middle estimate off by 1.6-fold (0.20 log units), on the high side; the range from low to high includes it.
By their numbers in this assay, from the lowest: compounds 3 and 1 (each within the scatter of the next); then compound 2.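

In this assay, the step of a 3.4-fold lower number from compound 2 to compound 3 (0.53 log units; beyond the scatter) isolates hydroxy in place of hydrogen on an aromatic carbon, ortho to a large group and para to a bromo group, and it lies beyond the scatter, on the side of higher toxicity in this test. The other single change, hydrogen in place of bromo on an aromatic carbon, gives a 1.2-fold lower number from compound 1 to compound 3 (0.08 log units; within the scatter) and lies within the scatter, so with hydroxy present the additional bromo group of compound 1 has no effect that can be read in this test. Of the two single changes now shown, only the hydroxy change separates two compounds by more than the scatter.

The data on hand give no reason for the size of the hydroxy step. On these data alone, how a methoxy group, an amine or a carboxylic acid would read on the same aromatic carbon stays open, as does whether the hydroxy step keeps its size with a chloro group in place of the bromo group.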